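The source may hold more compounds than are shown below. What is called first, only, known or untested is meant among the compounds shown, and "the series" means these compounds.

Working notes on the series

Compound 1 `C/C=C(\C)[C@H]1OC(=O)[C@@H](C)NC(=O)[C@H]([C@@H](C)CC)NC(=O)CN(C)C(=O)[C@@H](Cc2ccccc2)N(C)C(=O)[C@H](C)NC(=O)[C@@H](CC(C)C)OC(=O)/C(C)=C/C[C@H](O)[C@@H]1C` and compound 2 `C/C=C(\C)[C@@H](O)[C@@H](C)[C@@H]1C/C=C(\C)C(=O)O[C@H](CC(C)C)C(=O)N[C@@H](C)C(=O)N(C)[C@H](Cc2ccccc2)C(=O)N(C)CC(=O)N[C@@H]([C@@H](C)CC)C(=O)N[C@H](C)C(=O)O1` are built on two different cores; the difference between the two cores is not broken down here. Both carry an unsubstituted benzyl group. In a functional assay on K562 cells (Homo sapiens) for cytotoxicity, read by CellTiter-Blue, with a stated time of 72 h (a lower number here means a stronger inhibitor, a higher number a weaker inhibitor), compound 1 gives 0.0031 nM, and in this assay compound 2 gives 0.012 nM; the gap from compound 1 to compound 2 is beyond the usual scatter, so compound 2 stands as the weaker of the two measured parent compounds.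

Compound 3 `C/C=C(\C)[C@H]1OC(=O)[C@@H](C)NC(=O)[C@H]([C@@H](C)CC)NC(=O)CN(C)C(=O)[C@@H](Cc2ccc(Cl)cc2)N(C)C(=O)[C@H](C)NC(=O)[C@@H](CC(C)C)OC(=O)/C(C)=C/C[C@H](O)[C@@H]1C` is compound 1 with one change, (chloro in place of hydrogen on an aromatic carbon). In this assay compound 3 gives 0.000011 nM. Going by the values given here, the step of a 280-fold lower number from compound 1 to compound 3 (2.45 log units; beyond the scatter) is the only change in the set that is measured on both sides, and it is large.

Compound 4 `C/C=C(\C)[C@@H](O)[C@@H](C)[C@@H]1C/C=C(\C)C(=O)O[C@H](CC(C)C)C(=O)N[C@@H](C)C(=O)N(C)[C@H](Cc2ccc(Cl)cc2)C(=O)N(C)CC(=O)N[C@@H]([C@@H](C)CC)C(=O)N[C@H](C)C(=O)O1` is compound 2 with the same change, (chloro in place of hydrogen on an aromatic carbon), at a place described in the same words as for compound 3. It has not yet been measured in this assay.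

Expectation: since the step of a 280-fold lower number from compound 1 to compound 3 (2.45 log units; beyond the scatter) was large and the change into compound 4 is the same one on the other core, a step of similar direction is expected, though with only one earlier example its size is uncertain. The estimated step for compound 4 is a 120-fold lower number from compound 2 to compound 4 (2.08 log units; beyond the scatter). On that basis, compound 4 is expected to give about 0.0001 nM in this assay, most likely between 0.00002 nM and 0.001 nM.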

Compound 4, half-maximal inhibitory concentration: 0.000216 nM
Beside the measured number, compound 4's estimate is 2.2-fold (0.33 log units) below it; measured number inside the range.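

In this assay, chloro in place of hydrogen on an aromatic carbon, here benzyl to 4-chlorobenzyl, gives a 56-fold lower number from compound 2 to compound 4 (1.74 log units; beyond the scatter), so the change lowers the number on the core of compound 2 as it does on the core of compound 1, and the step is large on both. The direction carries across the two cores, but the size does not carry over intact, as the two steps stand apart: the same change on two cores in this assay, a 280-fold lower number (2.45 log units; beyond the scatter) from compound 1 to compound 3 and a 56-fold lower number (1.74 log units; beyond the scatter) from compound 2 to compound 4, 5.1-fold (0.71 log units) apart, beyond the scatter of two such steps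

This is a single pair of cores, so it shows that a step measured on one core was a fair guide to direction on the other, not that the change would act alike on any further core, and it does not tell which part of the difference between the two cores goes with the gap between the steps.

The compounds shown hold only hydrogen and chloro at this place on the ring, so it remains open whether fluoro, bromo, methoxy or an amine there would give a large step on either core. As far as these compounds go, it also remains open whether the gap between the two steps would hold for any of those groups.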